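This account rests on a few compounds, and the source may have more. Where it says the series, first, only, none or still open, it means among the compounds named here.

Among the compounds with values here, in a functional assay on the whole organism (strain Sprague-Dawley) for inhibition, with Rattus norvegicus as the target, with a stated time of 10 min (a lower number here means that less compound is needed, a higher number that more compound is needed for the effect), compound 1 `CCOC(=O)c1cnc(-c2ccccc2OCC)[nH]c1=O` gives 2 mg/kg and compound 2 `CCOC(=O)c1cnc(-c2cc(OC)ccc2OCC)[nH]c1=O` gives 0.3 mg/kg, so compound 2 holds the lower of the two numbers so far. Compound 3 `CCOC(=O)c1ccc(OCC)c(-c2ncc(C(=O)OCC)c(=O)[nH]2)c1` has not yet been measured. It departs from compound 2 at a single place, with ethoxycarbonyl in place of methoxy on an aromatic carbon. Within the data shown here, this carbon is the one that carries methoxy in compound 2 and hydrogen in compound 1, so only one measured step bears on the change. That step is a 6.7-fold lower number from compound 1 to compound 2 (0.82 log units; beyond the scatter), a modest move beyond the scatter. Among the measured compounds shown here, it shows that this place matters for compound 2, but no measurement yet shows how ethoxycarbonyl behaves there. Part of that gain may be lost, although a result close to compound 2 cannot be ruled out. A modest rise in this assay is therefore expected, and the estimated step is a 2.7-fold higher number from compound 2 to compound 3 (0.43 log units; beyond the scatter). Compound 3 is estimated at 0.8 mg/kg, with an expected range from 0.15 mg/kg to 4 mg/kg.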

Compound 3, dose for 50% inhibition: 1 mg/kg
The estimate for compound 3 lay 1.3-fold (0.10 log units) below the measured number; the measured number falls inside the stated range.
By their numbers in this assay, from the lowest: compound 2; then compounds 3 and 1 (each within the scatter of the next).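

In this assay, the carbon para to the ethoxy group does not treat every substituent alike: ethoxycarbonyl in place of methoxy gives a 3.3-fold higher number from compound 2 to compound 3 (0.52 log units; beyond the scatter), so the gain seen with methoxy does not carry over to this second group. Set against hydrogen at the same carbon, ethoxycarbonyl gives a 2.0-fold lower number from compound 1 to compound 3 (0.30 log units; within the scatter), and since this step lies within the scatter, the two cannot be told apart here, which leaves methoxy as the only one of the three groups that stands apart from both others. Nothing available explains this difference between methoxy and ethoxycarbonyl at this carbon.

The compounds shown leave open whether the gain belongs to methoxy alone or would also appear with a hydroxy group, a methyl group or a longer alkoxy chain, and how a carboxylic acid or an amine would behave at this carbon. They also leave open whether the same differences among the three groups would hold if the ethoxy group, or the ethoxycarbonyl group on the shared core, were replaced.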